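The compounds below may be only part of what the source reports. "The series", "measured", "known", "first", "only" and "open" are said of these compounds alone.

Working notes on the series. The compounds share one scaffold and vary mainly in the aromatic group that sits on the carbonyl carbon of the amide. Compound 1 `O=C(NCc1ccc(S(=O)(=O)c2cc(F)cc(F)c2)cc1)c1cc2cnccc2[nH]1` is read in an ADME assay on microsomes from liver (Mus musculus) for metabolic stability, read by LC-MS, with a stated time of 30 min, tested at 1 uM (a higher number here means that more of the compound is left, a lower number that less of the compound is left), at 63%. Compound 3 `O=C(NCc1ccc(S(=O)(=O)c2ccccc2)cc1)c1ccc2nncn2c1` gives 47% in this assay. Compound 2 `O=C(NCc1ccc(S(=O)(=O)N2CCCCC2)cc1)c1cc2ccncc2[nH]1` is the closest relative of the compound still to be tested. For compound 2 the read-out in this assay is reported only as "below limit of detection" (no number reported), with no number given. Compound 2 therefore has no single value on the scale and cannot be ranked against compound 1 or compound 3 on the numbers shown. Compound 4 `O=C(NCc1ccc(S(=O)(=O)N2CCCCC2)cc1)c1cc2cccnc2s1` is the next member, not yet measured. The change from compound 2 to compound 4 is a group of 9 heavy atoms (7 carbon, 1 nitrogen, 1 sulfur; one five-membered aromatic ring with 1 hetero atom, one six-membered aromatic ring with 1 hetero atom) in place of a group of 9 heavy atoms (7 carbon, 2 nitrogen; one five-membered aromatic ring with 1 hetero atom, one six-membered aromatic ring with 1 hetero atom), on a carbonyl carbon. Among the compounds with values here, no measured pair in the set isolates this change, so no step size is available from the data; with compound 2 giving no number, the direction and size of the step in this assay is open, and any expectation rests on compound 1 and compound 3 alone. Compound 4 is expected to land at about 45% in this assay, with a range from 10% to 80%.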

Compound 4, percent of the compound remaining: "below limit of detection" (no number reported)
The entry for compound 4 holds no number; no gap can be computed for the estimate.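

In this assay compound 2 and compound 4 are both reported only as below the limit of detection, so no step can be read between them. The compounds shown leave open how the exchange of the two bicyclic groups on the carbonyl carbon affects the compound remaining. No supporting data bear on this result.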